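Working notes: fluoro for ethyl on the shared core

This account rests on a few compounds, and the source may have more. Where it says the series, first, only, none or still open, it means among the compounds named here.

Measured in an ADME assay on QSG7701 cells (Homo sapiens) for inhibition, read by MTT assay, with a stated time of 48 h, tested at 50 uM; a higher number here means a stronger effect of the compound at the concentration tested, a lower number a weaker effect:
compound 1 `CCc1ccc2oc(-c3ccc(NC(=O)Nc4cccc(Cl)c4)cc3Cl)cc(=O)c2c1` — 12.6%
compound 2 `CCc1ccc2oc(-c3ccc(NC(=O)Nc4ccc(Cl)cc4)cc3Cl)cc(=O)c2c1` — 23.7%

Compound 1 stands lowest of the two numbers. Among the measured compounds shown here, the only measured step, a number 11.1 percentage points higher from compound 1 to compound 2 (beyond the scatter), concerns the group on the amide-type nitrogen and is of modest size. Compound 3 `O=C(Nc1cccc(Cl)c1)Nc1ccc(-c2cc(=O)c3cc(F)ccc3o2)c(Cl)c1` differs from compound 1 by fluoro in place of ethyl on an aromatic carbon. For the measured compounds named here, no measured step touches this aromatic carbon of the fused system, so nothing here points to a change beyond the scatter in this assay. For compound 3 the expected step is a number 1.4 percentage points higher from compound 1 to compound 3 (within the scatter). Compound 3 is therefore estimated at 14%, with a range from 3% to 30%.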

Compound 3, a percentage reported as inhibition, at one concentration (the size of the read-out at that concentration, not a potency): 26.8%
Compound 3: the middle estimate sits 12.8 percentage points below what was measured; measured number inside the range.
By their numbers in this assay, from the lowest: compound 1; then compounds 2 and 3 (each within the scatter of the next).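

In this assay, this aromatic carbon of the fused system is sensitive to substitution: fluoro in place of ethyl gives a number 14.2 percentage points higher from compound 1 to compound 3 (beyond the scatter). Among the compounds shown here, the earlier step concerned only the group on the amide-type nitrogen, so this is the first sign that the shared core also moves the number, by a modest step. No available data bear on why the number moves at this position.

Going by these compounds, whether the step follows from fluoro entering or from ethyl leaving remains open. A bare hydrogen, a methoxy group or an amine on this carbon would help separate the two, and the same change with the 4-chlorophenyl group would show whether the step carries over.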